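The compounds below may be only part of what the source reports. "The series", "measured", "known", "first", "only" and "open" are said of these compounds alone.

Working notes on the series. Going by the values given here, in a functional assay on A2780 cells (Homo sapiens) for antiproliferative activity, read by CellTiter-Glo, with a stated time of 72 h (on this read-out lower numbers stand for stronger inhibition and higher numbers for weaker inhibition), compound 1 `C[C@H](NC(=O)c1cccc(F)c1)c1ccc(NC(=O)N2CC(c3cccnc3)C2)cc1` gives 2.3 nM, the lowest of the three numbers so far. Compound 2 `C[C@H](NC(=O)C1CCOCC1)c1ccc(NC(=O)N2CC(c3cccnc3)C2)cc1` gives 17 nM, and compound 3 `C[C@H](NC(=O)[C@@H]1CCCN1C)c1ccc(NC(=O)N2CC(c3cccnc3)C2)cc1` gives 5.7 nM. Compound 4 `C[C@H](NC(=O)c1cccc(F)c1)c1ccc(NC(=O)N2CC(c3cncc(N)c3)C2)cc1` keeps the 3-fluorophenyl of compound 1 and carries amino in place of hydrogen on an aromatic carbon, turning pyridin-3-yl into 5-aminopyridin-3-yl: amino in place of hydrogen on an aromatic carbon. Among the compounds with values here, no measured step touches this place. The steps of a 7.4-fold higher number from compound 1 to compound 2 (0.87 log units; beyond the scatter), a 2.5-fold higher number from compound 1 to compound 3 (0.39 log units; beyond the scatter) and a 3.0-fold lower number from compound 2 to compound 3 (0.47 log units; beyond the scatter) all concern the group on the carbonyl carbon, so they show only how far this assay has moved within the series. A modest rise is expected, with low confidence, as the estimated 2.6-fold higher number from compound 1 to compound 4 (0.42 log units; beyond the scatter). For compound 4 the estimate is 6 nM, with an expected range of 1.5 nM to 25 nM.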

Compound 4, half-maximal inhibitory concentration: 240 nM
Compound 4: middle estimate off by 40-fold (1.60 log units), on the low side; the measured number lies above the stated range.
By their numbers in this assay, from the lowest: compound 1; then compound 3; then compound 2; then compound 4.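

The 5-aminopyridin-3-yl change shows that, in this assay, this ring position can move the number much further than any change on the carbonyl carbon has: a 100-fold higher number from compound 1 to compound 4 (2.02 log units; beyond the scatter). Going by these compounds alone, a single amino in place of hydrogen is enough to produce the largest step so far. No available evidence bears on the reason for this step.

Going by these compounds, whether methyl, fluoro or methoxy on this aromatic carbon would keep the number near that of compound 1 remains open. Also open, on these data alone, is whether amino has a similar effect with oxan-4-yl or 1-methylpyrrolidin-2-yl on the carbonyl carbon.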